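The source may report more compounds than this note shows. Statements on the series, on what has been measured and on what is new or still open speak of the compounds shown alone.

Compound 1, `O=C(CI)NCCCCCCC(=O)NCCCCCCNc1ncnc2c1ncn2[C@@H]1O[C@H](COP(=O)(O)OP(=O)(O)OP(=O)(O)O)[C@@H](O)[C@H]1O`, and compound 2, `O=C(CI)NCCCC(=O)NCCCCCCNc1ncnc2c1ncn2[C@@H]1O[C@H](COP(=O)(O)OP(=O)(O)OP(=O)(O)O)[C@@H](O)[C@H]1O`, share one core and differ only in the length of a chain that ends in an iodine-carrying amide. In an assay on isolated protein for inhibition of hexokinase-3 (Rattus norvegicus), with a stated time of 6 h, tested at 10 mM (a lower number here means less inhibition, a higher number more inhibition at the concentration tested (going by the name of the read-out)), compound 1 gives 0%, and in this assay compound 2 gives 0%, so neither shows any inhibition at the concentration tested. Going by the values given here, the one measured step, no change at the digits printed from compound 1 to compound 2 (within the scatter), shortened that chain and left the read-out where it was. Compound 2 therefore stands level with compound 1 on the numbers shown. Compound 3, `O=C(I)NCC(=O)NCCCCCCNc1ncnc2c1ncn2[C@@H]1O[C@H](COP(=O)(O)OP(=O)(O)OP(=O)(O)O)[C@@H](O)[C@H]1O`, shortens the same chain once more: a group of 4 heavy atoms (1 carbon, 1 nitrogen, 1 oxygen, 1 iodine; no ring) in place of a group of 7 heavy atoms (4 carbon, 1 nitrogen, 1 oxygen, 1 iodine; no ring), on a saturated chain carbon bound to a carbonyl carbon. Among the compounds with values here, the only step that bears on this change is no change at the digits printed from compound 1 to compound 2 (within the scatter), a shortening of the same kind that did not move the read-out beyond the scatter. A step of the same sort in this assay, that is none beyond the scatter, is therefore expected, no change at the digits printed from compound 2 to compound 3 (within the scatter). Compound 3 is accordingly estimated at 0% in this assay, with the estimate ranging from -5% to 10%.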

Compound 3, a percentage reported as inhibition, at one concentration (the size of the read-out at that concentration, not a potency): 0%
The estimate for compound 3 equals the measured number at the digits printed; the range from low to high includes it.
By their numbers in this assay, from the lowest: compounds 1, 2 and 3 (each within the scatter of the next).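

In this assay the further cut down to the group of 4 heavy atoms gives no change at the digits printed from compound 2 to compound 3 (within the scatter) and the whole span from the group of 10 heavy atoms gives no change at the digits printed from compound 1 to compound 3 (within the scatter) as well. The earlier pair covered a single shortening, whereas these three compounds show that on a saturated chain carbon bound to a carbonyl carbon, neither a second shortening nor the full range of chain lengths here brings any inhibition into view at the concentration tested. No measurement shown here offers an explanation for this flat result.

With all three compounds reading zero, the read-out cannot rank these chains, so it shows only that none of them gives inhibition under these conditions, not which of them comes closest to doing so. Going by these compounds alone, it remains open whether an amine or a carboxylic acid at the end of the chain in place of the iodine-carrying group, or a chain longer than the one in compound 1, would give a reading above zero in this assay at all.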